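The compounds below may be only part of what the source reports. "The series", "measured", "known", "first", "only" and "open" are said of these compounds alone.

Series notes on the pyrrolidinylmethoxy aryl ethers. Of the compounds shown here, two have been measured in an assay on HEK243 cells for displacement of a labelled ligand from Neuronal acetylcholine receptor; alpha3/beta4 (Homo sapiens), read by scintillation counting, with a stated time of 5 min; on this read-out lower numbers stand for stronger inhibition and higher numbers for weaker inhibition. Compound 1 `CN1CCC[C@H]1COc1cccc([N+](=O)[O-])c1` gives 946 nM in this assay, the higher of the two numbers. Compound 2 `CN1CCC[C@H]1COc1cc(O)cc(-c2ccc(O)cc2)c1` gives 30 nM in this assay, and the gap between the two lies beyond the scatter. Compound 2 carries a hydroxy group and a 4-hydroxyphenyl group where compound 1 carries a nitro group, so the two differ in more than one place and no single step can be read from that pair.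

Compound 3 `CN1CCC[C@H]1COc1cc(-c2ccc(O)cc2)cc([N+](=O)[O-])c1` remains to be measured. It differs from compound 1 by 4-hydroxyphenyl in place of hydrogen on an aromatic carbon. The nitro group of compound 1 is kept in compound 3, while the 4-hydroxyphenyl group is shared with compound 2. Within the data shown here, no pair differing in one place is available, so the size of the step is uncertain. Judging from compound 1 at 946 nM against compound 2 at 30 nM, a drop beyond the scatter is expected. The step expected is a 16-fold lower number from compound 1 to compound 3 (1.20 log units; beyond the scatter). Compound 3 is estimated at 60 nM in this assay, expected to fall between 20 nM and 200 nM.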

Compound 3, inhibition constant: 122 nM
Beside the measured number, compound 3's estimate is 2.0-fold (0.31 log units) below it; the measured number falls inside the stated range.
By their numbers in this assay, from the lowest: compound 2; then compound 3; then compound 1.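

In this assay, 4-hydroxyphenyl on the aromatic carbon meta to a nitro group and meta to a (1-methylpyrrolidin-2-yl)methoxy group gives a 7.8-fold lower number from compound 1 to compound 3 (0.89 log units; beyond the scatter), a single change that the earlier pair could not isolate, and the drop beyond the scatter occurs with the nitro group kept in place. With 4-hydroxyphenyl held fixed, nitro in place of hydroxy on an aromatic carbon gives a 4.1-fold higher number from compound 2 to compound 3 (0.61 log units; beyond the scatter), so the two steps separate the two differences between compound 1 and compound 2, and both lie beyond the scatter. Nothing measured on these compounds bears on the reason for either step.

Whether the step from hydrogen depends on the whole 4-hydroxyphenyl group or on its hydroxy group stays open, with no plain phenyl among the compounds shown. Also open, going by these compounds, are how an amine or a carboxylic acid would read on the carbon that carries nitro in compound 3, and whether the step between nitro and hydroxy keeps its size without the 4-hydroxyphenyl group.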